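Swapping the hydroxyethyl ether for a pyridylmethyl ether

The compounds below may be only part of what the source reports. "The series", "measured", "known", "first", "only" and "open" are said of these compounds alone.

Compound 3 `O=C1NCc2c1c1c(c3c2c2ccccc2n3CCO)CCc2cc(OCCO)ccc2-1` stands highest of the three numbers in an assay on isolated protein for inhibition of mitogen-activated protein kinase kinase kinase 11 (Homo sapiens), tested at 1 uM (a higher number here means more inhibition at the concentration tested (going by the name of the read-out), a lower number less inhibition), giving 46%. Compound 1 `O=C1NCc2c1c1c(c3c2c2ccccc2n3CCO)CCc2cc(OC3CCCC3)ccc2-1` gives 32% in this assay, and compound 2 `N#CCOc1ccc2c(c1)CCc1c-2c2c(c3c4ccccc4n(CCO)c13)CNC2=O` gives 8%. Two measured steps lead to compound 3: a number 14 percentage points higher from compound 1 to compound 3 (beyond the scatter) and a number 38 percentage points higher from compound 2 to compound 3 (beyond the scatter). Compound 4 `O=C1NCc2c1c1c(c3c2c2ccccc2n3CCO)CCc2cc(OCc3ccccn3)ccc2-1` differs from compound 3 by pyridin-2-yl in place of hydroxymethyl on a saturated chain carbon bound to an oxygen on an aromatic ring. Both steps bear on this change, since each brought in the hydroxyl group that compound 4 now gives up, and the step from compound 2 was the larger of the two. A downward step beyond the scatter is therefore expected, estimated as a number 21 percentage points lower from compound 3 to compound 4 (beyond the scatter). Compound 4 is expected to give about 25% in this assay, with a range from 5% to 50%.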

Compound 4, a percentage reported as inhibition, at one concentration (the size of the read-out at that concentration, not a potency): 30%
Compound 4: the middle estimate sits 5 percentage points below what was measured; the measured number falls inside the stated range.
By their numbers in this assay, from the lowest: compound 2; then compounds 4 and 1 (each within the scatter of the next); then compound 3.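

Replacing hydroxymethyl with pyridin-2-yl on this saturated chain carbon gives, in this assay, a number 16 percentage points lower from compound 3 to compound 4 (beyond the scatter), so the hydroxyl-bearing ether remains the best of the groups shown. Against the nitrile, the same ring gives a number 22 percentage points higher from compound 2 to compound 4 (beyond the scatter), while against the cyclopentyl ether the change gives a number 2 percentage points lower from compound 1 to compound 4 (within the scatter), which places two ring-bearing ethers of quite different kinds level. Nothing available explains these steps. The compounds shown leave open whether a benzyl ether, without the ring nitrogen, would match compound 4, and how a 2-aminoethyl ether or a longer hydroxyalkyl chain would compare with compound 3.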